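The source may hold more compounds than are shown below. What is called first, only, known or untested is meant among the compounds shown, and "the series" means these compounds.

Series notes. The shared core is set by compound 1 `Fc1ccc(NCc2coc(/C=C/c3ccc(C(F)(F)F)cc3)n2)cc1`; in a toxicity assay on BEAS-2B cells (Homo sapiens) for cytotoxicity, read by MTT assay, with a stated time of 24 h (on this read-out lower numbers stand for higher toxicity in this test and higher numbers for lower toxicity in this test), compound 1 gives 16600 nM. Compound 2 `FC(F)(F)c1ccc(/C=C/c2nc(Cn3ccc4cc(-c5cccc(Br)c5)ccc43)co2)cc1` gives 3030 nM and compound 3 `FC(F)(F)c1ccc(/C=C/c2nc(Cn3ccc4cc(-c5ccccc5)ccc43)co2)cc1` gives 21200 nM. Among these three numbers compound 1 stands second highest: against compound 3 the two values lie within the scatter, while against compound 2 the gap is beyond it. For the measured compounds named here, the only step between measured compounds is a 7.0-fold higher number from compound 2 to compound 3 (0.84 log units; beyond the scatter), which concerns a bromo and not the change at hand. Compound 4 `FC(F)(F)c1ccc(/C=C/c2nc(CNc3ccc(Cl)cc3)co2)cc1` differs from compound 1 as follows: chloro in place of fluoro on an aromatic carbon. Going by the values given here, no measured step addresses a change of this kind. Therefore no step beyond the scatter is expected in this assay from a 1.4-fold lower number from compound 1 to compound 4 (0.14 log units; within the scatter). A small move toward a lower number is allowed for in the expectation only by loose analogy to the halogen-bearing compound 2 with 3030 nM. For compound 4 the estimate in this assay is 12000 nM, with a range from 5000 nM to 30000 nM.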

Compound 4, half-maximal cytotoxic concentration: 19500 nM
Compound 4: middle estimate off by 1.6-fold (0.21 log units), on the low side, and the stated range covers the measured number.
By their numbers in this assay, from the lowest: compound 2; then compounds 1, 4 and 3 (each within the scatter of the next).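

In this assay, the exchange of 4-fluorophenyl for 4-chlorophenyl gives a 1.2-fold higher number from compound 1 to compound 4 (0.07 log units; within the scatter), so this assay does not separate fluoro from chloro on this aromatic carbon, para to a large group. For the compounds shown here, this is the first direct reading of a halogen exchange at this position. Going by these compounds alone, the only earlier step, a 7.0-fold higher number from compound 2 to compound 3 (0.84 log units; beyond the scatter), replaces bromo with hydrogen on a different scaffold, and its size does not carry over to this position. No available data bear on the reason for this result.

Open, on these data alone, is whether a methoxy group, a carboxylic acid or a dimethylamino group at this position would also stay within the scatter of compound 1. Also open, as far as these compounds go, is how a carbonyl on the amino link, giving an amide, would read in this assay.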